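The source may hold more compounds than are shown below. What is called first, only, known or untested is meant among the compounds shown, and "the series" means these compounds.

Three esters sharing one core have been measured in an assay on NIH3T3 cells with Urotensin-2 receptor (Homo sapiens) as the target; a lower number here means a smaller maximal response, a higher number a larger maximal response. Compound 1 `CCc1ccccc1C(=O)OC(CCN(C)C)c1ccc(Cl)cc1` gives 128% and compound 2 `Cc1c(Cl)cccc1C(=O)OC(CCN(C)C)c1ccc(Cl)cc1` gives 118%. Compound 3 `Cc1ccc(C)c(C(=O)OC(CCN(C)C)c2ccc(Cl)cc2)c1` gives 86%, the lowest of the three numbers; its nearest neighbour is compound 2 and its furthest is compound 1, and both gaps lie beyond the scatter. The steps leading to it were large: a number 42 percentage points lower from compound 1 to compound 3 (beyond the scatter) and a number 32 percentage points lower from compound 2 to compound 3 (beyond the scatter), whereas a number 10 percentage points lower from compound 1 to compound 2 (within the scatter).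

Compound 4 `Cc1cc(C)c(C(=O)OC(CCN(C)C)c2ccc(Cl)cc2)cc1C` is not yet measured. It differs from compound 3 in one place: methyl in place of hydrogen on an aromatic carbon. Within the data shown here, no measured pair isolates a single added methyl, so the two large steps that end at compound 3 bear on the question only loosely: they show that changing the substitution of the aromatic ring on the carbonyl carbon can move the maximal response strongly, in either sense, but they do not say which way one more methyl on that ring would push it. Without a direct precedent, a step within the scatter is the most defensible expectation, with wide uncertainty.

Compound 4 is therefore expected to give 82%, estimated to fall between 55% and 112%. This corresponds to an expected step of a number 4 percentage points lower from compound 3 to compound 4 (within the scatter).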

Compound 4, largest response reached (reported as efficacy), in percent of the reference or control that the assay uses: 60%
For compound 4 the middle estimate is 22 percentage points above the measured one; low and high end bracket the measured number.
By their numbers in this assay, from the lowest: compound 4; then compound 3; then compounds 2 and 1 (each within the scatter of the next).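

The earlier compounds shown here showed only that swapping substituents on the ring attached to the carbonyl carbon could shift the maximal response. A single added methyl is now isolated in one pair: in this assay, methyl in place of hydrogen on an aromatic carbon that is ortho to a methyl group, meta to a methyl group and para to a large group gives a number 26 percentage points lower from compound 3 to compound 4 (beyond the scatter), so one extra carbon at this position is enough to lower the maximal response by more than the usual scatter. Nothing available here explains this drop.

The compounds shown do not tell whether the fall belongs to methyl in particular or would also appear with a different group on this carbon, such as a methoxy group, an amine or a carboxylic acid. They also leave open whether the same added methyl would lower the maximal response in the same way on the differently substituted rings of compound 1 and compound 2.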